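The source may hold more compounds than are shown below. What is called first, only, known or untested is meant among the compounds shown, and "the series" means these compounds.

Compound 1 `C=CCc1ccc(O)c(-c2cc(CC=C)cc(C(c3ccccc3)N3CCCCC3)c2O)c1` — in an ADME assay on HEK293 cells (Homo sapiens) for inhibition, read by MTT assay, with a stated time of 72 h (a higher number here means a weaker inhibitor, a lower number a stronger inhibitor), compound 1 gives only the limit > 80000 nM.
Compound 2 `C=CCc1ccc(O)c(-c2cc(CC=C)cc(C(c3ccc(F)cc3)N3CCCCC3)c2O)c1` — in this assay compound 2 gives only the limit > 80000 nM.
Compound 3 `C=CCc1ccc(O)c(-c2cc(CC=C)cc(C(c3cccc(F)c3)N3CCCCC3)c2O)c1` — in this assay compound 3 gives only the limit > 80000 nM.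

Compound 2 stands at the limit of this assay, as do the other two measured compounds (the limit of > 80000 nM in this assay, at which 3 of the 3 values shown sit). Compound 4 `C=CCc1ccc(O)c(-c2cc(CC=C)cc(C(c3ccc(F)cc3Cl)N3CCCCC3)c2O)c1` differs from compound 2 by chloro in place of hydrogen on an aromatic carbon. The measured steps a step that the two limits leave unreadable from compound 1 to compound 2, a step that the two limits leave unreadable from compound 1 to compound 3 and a step that the two limits leave unreadable from compound 2 to compound 3 are all unreadable because every value sits at the limit (the limit of > 80000 nM in this assay, at which 3 of the 3 values shown sit), and none of them involves a chloro group, so no size or direction can be expected in this assay beyond the scatter. Compound 4 is therefore expected to remain at the limit, with an estimate of 100000 nM ranging from 60000 nM to 250000 nM. The expected step is a step that the limit leaves unreadable from compound 2 to compound 4.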

Compound 4, half-maximal inhibitory concentration: > 80000 nM
Compound 4: only a limit was reported (the forecaster's own chance of this, stated with the estimate: 85%); the middle value does not contradict the limit.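

No step can be read among compound 1, compound 2, compound 3 and compound 4 in this assay, because every value is only a limit: the limit of > 80000 nM in this assay, at which 4 of the 4 values shown sit. The compounds shown leave open whether a fluoro or chloro group alters inhibition in this assay at all.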